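The source may report more compounds than this note shows. Statements on the series, on what has been measured and on what is new or still open speak of the compounds shown alone.

Compounds measured so far:
Compound 1 `c1c[nH]c(-c2ccccc2OCC2=NCCN2)c1` — 1.26 nM
Compound 2 `c1ccc(-c2ccoc2)c(OCC2=NCCN2)c1` — 0.501 nM

Both were tested in a functional assay for activation of Alpha-1A adrenergic receptor (Homo sapiens), read by calcium flux; a lower number here means that less compound is needed, a higher number that more compound is needed for the effect. Compound 2 stands at the lowest of the two numbers; its nearest neighbour is compound 1, and the step of a 2.5-fold lower number from compound 1 to compound 2 (0.40 log units; beyond the scatter) lies beyond the scatter. Compound 3 `c1ccc(-c2ccsc2)c(OCC2=NCCN2)c1` differs from compound 2 by thiophen-3-yl in place of furan-3-yl on an aromatic carbon. For the measured compounds named here, the only measured step exchanges one five-membered aromatic ring for another at the same position, and no step swaps the oxygen ring for a sulfur ring, so the exchange in compound 3 is expected to shift the number little, if at all, beyond the scatter. Compound 3 is therefore estimated at 0.5 nM, ranging from 0.2 nM to 1.3 nM, an expected step of a 1.0-fold lower number from compound 2 to compound 3 (0.00 log units; within the scatter).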

Compound 3, half-maximal effective concentration: 0.251 nM
Compound 3: the middle estimate sits 2.0-fold (0.30 log units) above what was measured; low and high end bracket the measured number.
By their numbers in this assay, from the lowest: compounds 3 and 2 (each within the scatter of the next); then compound 1.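

In this assay, exchanging the oxygen ring for the sulfur ring on this aromatic carbon gives a 2.0-fold lower number from compound 2 to compound 3 (0.30 log units; within the scatter), so thiophen-3-yl and furan-3-yl are not told apart at this position. Against 1H-pyrrol-2-yl, thiophen-3-yl gives a 5.0-fold lower number from compound 1 to compound 3 (0.70 log units; beyond the scatter), so a second group now stands beyond the scatter from the pyrrole. Nothing available explains either step.

Whether the separation from 1H-pyrrol-2-yl follows from its ring atom or its point of attachment remains open, as 1H-pyrrol-3-yl is not among these compounds. Also open, from the compounds shown here alone, is how a phenyl ring or an amine would behave in this place.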